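Replacing nitro with chloro: what to expect

This account rests on a few compounds, and the source may have more. Where it says the series, first, only, none or still open, it means among the compounds named here.

- compound 1 `COc1ccc(/C=C2\SC(=O)N(CCNC(=O)Nc3c(C)n(C)n(-c4ccccc4)c3=O)C2=O)cc1` gives 13900 nM
- compound 2 `COc1ccc(/C=C2\SC(=O)N(CC(=O)Nc3c(C)n(C)n(-c4ccccc4)c3=O)C2=O)cc1` gives 93700 nM
- compound 3 `Cc1c(NC(=O)CN2C(=O)S/C(=C\c3ccc([N+](=O)[O-])cc3)C2=O)c(=O)n(-c2ccccc2)n1C` gives > 100000 nM, a limit of the assay

All three compounds were tested in a functional assay on PC-3 cells (Homo sapiens) for inhibition, read by MTT assay, with a stated time of 48 h; on this read-out lower numbers stand for stronger inhibition and higher numbers for weaker inhibition. Compound 3 sits at the limit of > 100000 nM in this assay, at which 1 of the 3 values shown sits, so it has no exact number, only a limit.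

Compound 4 `Cc1c(NC(=O)CN2C(=O)S/C(=C\c3ccc(Cl)cc3)C2=O)c(=O)n(-c2ccccc2)n1C` differs from compound 3 in one place: chloro in place of nitro on an aromatic carbon, para to a large group (chloro in place of nitro on an aromatic carbon). In other words, 4-nitrophenyl becomes 4-chlorophenyl.

Among the compounds with values here, only one measured step changes this same group. It shows an at least 1.0-fold higher number from compound 2 to compound 3 (0.02 log units; that floor lies within the scatter). On these data alone, since that figure is a floor, the true size of the step remains unknown. Compound 1 carries a different chain, so it says little about this exchange, even though its number is the lowest of the three.

The nearest exact number is therefore that of compound 2 at 93700 nM, and a result in that high region is expected here, with no large step in either direction. The expected step is an at least 1.4-fold lower number from compound 3 to compound 4 (0.15 log units; that floor lies within the scatter). For compound 4 the estimated value is 70000 nM, with an expected range of 28000 nM to 100000 nM.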

Compound 4, half-maximal inhibitory concentration: 28900 nM
Compound 4: middle estimate off by 2.4-fold (0.38 log units), on the high side; low and high end bracket the measured number.
By their numbers in this assay, from the lowest: compound 1; then compound 4; then compound 2. At a limit, above all of these: compound 3.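

Until now this position on the aromatic ring had offered one step, with a floor inside the scatter, so it was unclear whether the group there mattered at all. In this assay, chloro in place of nitro gives an at least 3.4-fold lower number from compound 3 to compound 4 (0.53 log units; beyond the scatter), and chloro in place of methoxy gives a 3.2-fold lower number from compound 2 to compound 4 (0.51 log units; beyond the scatter), so with the chain held constant, the group at this position does move the number, and chloro gives the lowest number of these three groups. The first of these steps is only a floor, because compound 3 has a limit and not an exact number: the limit of > 100000 nM in this assay, at which 1 of the 4 values shown sits.

The compounds shown leave open whether chloro would bring the same kind of drop on the different chain of compound 1, which appears here only with methoxy. They also leave open how other groups at this position, such as an amine, a carboxylic acid or a fluoro group, would compare with chloro, and so whether the number can fall further through this position alone.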